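The source may report more compounds than this note shows. Statements on the series, on what has been measured and on what is new or still open speak of the compounds shown alone.

Of the compounds shown here, three have been measured in a functional assay on A-431 cells (Homo sapiens) for cytotoxicity, read by MTT assay, with a stated time of 72 h, tested at 1 uM; a lower number here means less inhibition of growth, a higher number more inhibition of growth at the concentration tested. Compound 1 `Cc1ccnc(/C(N)=N/NC(=S)N2CCN(c3ccccn3)CC2)c1` gives 28.9%. Compound 2 `Cc1cccc(/C(N)=N/NC(=S)N2CCCC2)n1` gives 21%, and compound 3 `N/C(=N\NC(=S)N1CCCC1)c1ccccn1` gives 39.8%. How the core of compound 1 and the core of compound 2 differ is not broken down here.

Compound 2 and compound 3 differ in one place: hydrogen in place of methyl on an aromatic carbon. This change made a step of a number 18.8 percentage points higher from compound 2 to compound 3 (beyond the scatter).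

Compound 4 `N/C(=N\NC(=S)N1CCN(c2ccccn2)CC1)c1ccccn1` is not yet measured. It is related to compound 1 by the same kind of change: hydrogen in place of methyl on an aromatic carbon. The surroundings are not identical, though: in compound 2 the methyl sits next to the ring nitrogen, while in compound 1 it sits opposite the ring nitrogen.

Resting on the step from compound 2 to compound 3, a rise of about a number 12.1 percentage points higher from compound 1 to compound 4 (beyond the scatter) is expected from compound 1 to compound 4, though the different place of the methyl leaves room for a smaller step. For compound 4 in this assay a value of about 41% is estimated, most likely between 25% and 57%.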

Compound 4, percent growth inhibition at one concentration: 11.6%
Compound 4: middle estimate off by 29.4 percentage points, on the high side; the measured number lies below the stated range.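

In this assay, replacing methyl with hydrogen gave a number 17.3 percentage points lower from compound 1 to compound 4 (beyond the scatter), so the change did not carry over from one core to the other with the same direction, as the two steps side by side show: the same change on two cores in this assay, a number 18.8 percentage points higher (beyond the scatter) from compound 2 to compound 3 and a number 17.3 percentage points lower (beyond the scatter) from compound 1 to compound 4, 36.1 percentage points apart, beyond the scatter of two such steps

This does not show what reverses the direction, since the two pairs differ both in the rest of the core and in where the methyl sits, opposite the ring nitrogen in compound 1 but elsewhere in compound 2. With a single pair on each core and a read-out at one concentration, the result only warns that a step seen on one core in this series is a poor guide to the same change on another.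

The compounds shown leave open how a methoxy group or a chlorine atom would behave at this place, since only methyl and hydrogen appear there. They also leave open what a methyl opposite the ring nitrogen would do on the core of compound 3, a comparison that would separate the effect of its place from that of the rest of the core.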